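The source may report more compounds than this note shows. Statements on the series, on what has been measured and on what is new or still open speak of the compounds shown alone.

Measured so far:
compound 1 `O=C(NCCNS(=O)(=O)c1ccc(-c2ccccc2Oc2ccc(O)c(O)c2)s1)Nc1cc(Cl)cc(Cl)c1` — > 20000 nM
compound 2 `O=S(=O)(NCCNC(=S)Nc1ccc(Cl)cc1)c1ccc(-c2ccccc2OCc2ccccc2)s1` — 7000 nM

The value of compound 1 in a functional assay on HeLa cells (Homo sapiens) for inhibition, read by CCK-8 assay, with a stated time of 48 h (a lower number here means a stronger inhibitor, a higher number a weaker inhibitor), is a limit of the assay and not a number (the limit of > 20000 nM in this assay, at which 1 of the 2 values shown sits). Among the compounds with values here, compound 2 holds the only number seen in this assay, so no measured step gives a scale for the series. Compound 3 `O=C(NCCNS(=O)(=O)c1ccc(-c2ccccc2OCc2ccccc2)s1)Nc1cc(Cl)cc(Cl)c1` differs from compound 2 in one place: a group of 11 heavy atoms (7 carbon, 1 nitrogen, 1 oxygen, 2 chlorine; one six-membered aromatic ring of carbon only) in place of a group of 10 heavy atoms (7 carbon, 1 nitrogen, 1 sulfur, 1 chlorine; one six-membered aromatic ring of carbon only), on an amine nitrogen. Within the data shown here, no measured step covers this change; a step in either direction beyond the scatter cannot be ruled out, and none is clearly indicated. Compound 3 is expected at 8000 nM, within 2500 nM to 25000 nM, an expected step of a 1.1-fold higher number from compound 2 to compound 3 (0.06 log units; within the scatter).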

Compound 3, half-maximal inhibitory concentration: > 20000 nM
Compound 3: no number, only a limit; the forecaster's own chance of this, stated with the estimate: 30%; middle value at least 2.5-fold (0.39 log units) away from the limit.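

In this assay the (3,5-dichlorophenyl)carbamoyl group on the amine nitrogen gives an at least 2.8-fold higher number from compound 2 to compound 3 (0.45 log units; beyond the scatter) and shows that this position is sensitive to the group it carries. The value of compound 3 is a limit of the assay and not a number: the limit of > 20000 nM in this assay, at which 2 of the 3 values shown sit. The step involving compound 1 and compound 3 cannot be read.

The change swaps sulfur for oxygen and alters the chlorine count together, and the compounds shown do not separate the two. As far as these compounds go, how a pyridyl ring or a carboxylic acid at this nitrogen would read remains open.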